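Returning from an indane amine to a phenyl-bearing amine

The source may report more compounds than this note shows. Statements on the series, on what has been measured and on what is new or still open speak of the compounds shown alone.

Compound 3 `c1ccc2c(c1)CCC2NCC1CCN(CCCc2c[nH]c3ccc(-n4cnnc4)cc23)CC1` stands lowest of the three measured compounds in a functional assay on CHO cells for activation of 5-hydroxytryptamine receptor 1D (Homo sapiens), read by GTPgammaS binding (a higher number here means a larger maximal response, a lower number a smaller maximal response), where compound 3 gives 78%. Compound 1 `COC[C@H](NC1CCN(CCCc2c[nH]c3ccc(-n4cnnc4)cc23)CC1)c1ccccc1` gives 93% and compound 2 `C[C@@H](NC1CCN(CCCc2c[nH]c3ccc(-n4cnnc4)cc23)CC1)c1ccccc1` gives 90%; these two lie within the scatter of each other. Compound 4 `CC(CO)(NC1CCN(CCCc2c[nH]c3ccc(-n4cnnc4)cc23)CC1)c1ccccc1` has not yet been measured. The change is (1-(hydroxymethyl)-1-phenylethyl)amino in place of ((2,3-dihydro-1H-inden-1-yl)amino)methyl on a saturated ring carbon. Like compounds 1 and 2, compound 4 carries an amino group on the saturated ring carbon rather than the ((2,3-dihydro-1H-inden-1-yl)amino)methyl of compound 3, so the relevant steps run the other way: a number 15 percentage points lower from compound 1 to compound 3 (beyond the scatter) and a number 12 percentage points lower from compound 2 to compound 3 (beyond the scatter). For compound 4 a modest rise beyond the scatter is therefore expected, a number 10 percentage points higher from compound 3 to compound 4 (within the scatter). Compound 4 is estimated at 88%, with a range from 75% to 100%.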

Compound 4, largest response reached (reported as efficacy), in percent of the reference or control that the assay uses: 59%
Compound 4: the middle estimate sits 29 percentage points above what was measured, and the stated range ends above it.
By their numbers in this assay, from the lowest: compound 4; then compound 3; then compounds 2 and 1 (each within the scatter of the next).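

A phenyl-bearing amine on the saturated ring carbon does not by itself restore the response in this assay, since the step to 1-(hydroxymethyl)-1-phenylethyl amino gives a number 19 percentage points lower from compound 3 to compound 4 (beyond the scatter). On the amine nitrogen, the size of the change depends on the group: 1-(hydroxymethyl)-1-phenylethyl gives a number 31 percentage points lower from compound 2 to compound 4 (beyond the scatter) and a number 34 percentage points lower from compound 1 to compound 4 (beyond the scatter), while 1-phenylethyl gave a number 3 percentage points lower from compound 1 to compound 2 (within the scatter). Nothing available explains these drops.

A 1-methyl-1-phenylethyl or a 2-hydroxy-1-phenylethyl group on that nitrogen could help separate the part played by the hydroxyl from that of the extra methyl group.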